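Swapping chlorophenyl for a methylindole on the shared core

A few compounds are considered here, and "the series" means these few. Any claim that something is new, unique, unknown or untested is made for them only; others in the source may bear on it.

Compound 1 `COc1cc(-c2ccnc3cc(-c4ccc(Cl)cc4)nn23)cc(OC)c1OC` stands at the top of the two measured numbers: in a functional assay on A549 cells (Homo sapiens) for inhibition, read by CCK-8 assay, with a stated time of 48 h (a lower number here means a stronger inhibitor, a higher number a weaker inhibitor), compound 1 gives 3070 nM. Among the compounds with values here, compound 2 `COc1cc(-c2ccnc3cc(-c4ccc5c(ccn5C)c4)nn23)cc(OC)c1OC` carries 1-methyl-1H-indol-5-yl in place of 4-chlorophenyl, and in this assay compound 2 gives 15 nM; the step of a 200-fold lower number from compound 1 to compound 2 (2.31 log units; beyond the scatter) is the only measured step and it bears directly on the question. Compound 3 `COc1cc(-c2ccnc3cc(-c4ccc5ccn(C)c5c4)nn23)cc(OC)c1OC` is the unmeasured compound: 1-methyl-1H-indol-6-yl in place of 4-chlorophenyl on an aromatic carbon. Within the data shown here, the entering group is an isomer of the one in compound 2, so a step in the same direction is expected, although its size is less certain with no second example. The step from compound 1 to compound 3 is expected to be a 51-fold lower number from compound 1 to compound 3 (1.71 log units; beyond the scatter) because the step of a 200-fold lower number from compound 1 to compound 2 (2.31 log units; beyond the scatter) was large. Compound 3 is therefore estimated at 60 nM, with a range from 10 nM to 400 nM.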

Compound 3, half-maximal inhibitory concentration: 829 nM
The estimate for compound 3 lay 14-fold (1.14 log units) below the measured number, outside the stated range (above it).
By their numbers in this assay, from the lowest: compound 2; then compound 3; then compound 1.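

In this assay, exchanging 1-methyl-1H-indol-5-yl for its isomer 1-methyl-1H-indol-6-yl gives a 55-fold higher number from compound 2 to compound 3 (1.74 log units; beyond the scatter), so at this carbon of the shared core the outcome depends strongly on which indole isomer is attached, and not merely on the presence of a methylindole. The 1-methyl-1H-indol-6-yl group still improves on 4-chlorophenyl, with a 3.7-fold lower number from compound 1 to compound 3 (0.57 log units; beyond the scatter), but that gain is far smaller than the one that the 5-yl isomer gives. Nothing available here accounts for the gap between the two isomers.

Going by these compounds, it remains open how a 1H-indol-5-yl group, with hydrogen in place of the methyl, would compare with the 1-methyl-1H-indol-5-yl group. Also open, on these data alone, is whether a benzofuran-5-yl group, with oxygen in place of the ring nitrogen, would keep the low number of compound 2 15 nM in this assay.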